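The compounds below may be only part of what the source reports. "The series", "measured", "known", "first", "only" and "open" are said of these compounds alone.

Two compounds of the series carry measurements so far. Compound 1 `CC1=CC[C@H]2[C@H](CC[C@]2(C)O)C(C)(C)[C@@H]1CC[C@H]1[C@]2(C)CC[C@H](OC(=O)c3ccccc3)C(C)(C)O[C@H]2CC[C@@]1(C)O` in a functional assay on MCF7 cells (Homo sapiens) for antiproliferative activity, read by MTT assay, with a stated time of 72 h (a higher number here means a weaker inhibitor, a lower number a stronger inhibitor), gives 21000 nM. Compound 2 `CC1=CC[C@H]2[C@@H]1CC=C(C)[C@@H](CC[C@H]1[C@]3(C)CC[C@H](OC(=O)c4ccccc4)C(C)(C)O[C@H]3CC[C@@]1(C)O)C2(C)C` in this assay gives 23100 nM. Compound 1 stands at the low end of these two numbers, though the two values lie within the scatter of each other, so nothing separates compound 1 from compound 2 on this evidence. Compound 3 `CC1=CC[C@H]2[C@H](CC[C@]2(C)O)C(C)(C)[C@@H]1CC[C@H]1[C@]2(C)CC[C@H](OC(=O)c3cccc([N+](=O)[O-])c3)C(C)(C)O[C@H]2CC[C@@]1(C)O` remains to be measured. It differs from compound 1 in one place: nitro in place of hydrogen on an aromatic carbon. Within the data shown here, no measured pair shows this change, so its effect has no anchor in the data. In this assay the expected step is a 1.2-fold lower number from compound 1 to compound 3 (0.07 log units; within the scatter), small, of uncertain direction and probably not beyond the scatter. Compound 3 is therefore estimated at 18000 nM, with a range from 7000 nM to 45000 nM.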

Compound 3, half-maximal inhibitory concentration: 36000 nM
Beside the measured number, compound 3's estimate is 2.0-fold (0.30 log units) below it; the range from low to high includes it.
By their numbers in this assay, from the lowest: compounds 1, 2 and 3 (each within the scatter of the next).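

In this assay, among these compounds, the step for nitro in place of hydrogen on the aromatic carbon is a 1.7-fold higher number from compound 1 to compound 3 (0.23 log units; within the scatter), the first reading of any change on this benzoyl ring. Going from benzoyl to (3-nitrophenyl)carbonyl therefore leaves compound 3 not separated from compound 1, and this single pair shows no effect of the change at this position beyond the scatter. No available evidence bears on this result.

On these data alone, whether an amine or a carboxylic acid on the same aromatic carbon would give a step beyond the scatter remains open. Also open, as far as these compounds go, is whether nitro in place of hydrogen would give a similar step on the core of compound 2.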